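The source may hold more compounds than are shown below. What is called first, only, known or untested is meant among the compounds shown, and "the series" means these compounds.

Measured compounds in a physicochemical assay for lipophilicity; a higher number here means a more lipophilic compound, a lower number a more polar compound:
- compound 1, `Cc1cn(C2CC(N=[N+]=[N-])C(COC(=O)NCCCC(=O)O)O2)c(=O)[nH]c1=O`: -0.81
- compound 2, `CCCCOC(=O)OCC1OC(n2cc(C)c(=O)[nH]c2=O)CC1N=[N+]=[N-]`: 1.02
- compound 3, `Cc1cn(C2CC(N=[N+]=[N-])C(COC(=O)OCCO)O2)c(=O)[nH]c1=O`: -1.2

Compound 1 stands second highest of the three: compound 3 is its nearest neighbour, a number 0.39 log units lower from compound 1 to compound 3 (beyond the scatter), and compound 2 is furthest, a number 1.83 log units higher from compound 1 to compound 2 (beyond the scatter).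

The next compound, compound 4, `Cc1cn(C2CC(N=[N+]=[N-])C(COC(=O)OCCCO)O2)c(=O)[nH]c1=O`, is not yet measured in this assay. Its difference from compound 1 is 3-hydroxypropoxy in place of (3-carboxypropyl)amino on a carbonyl carbon. The same difference, cut one bond further out, reads: (3-carboxypropyl)carbamoyl to (3-hydroxypropoxy)carbonyl.

The closest measured step is a number 0.39 log units lower from compound 1 to compound 3 (beyond the scatter), where 2-hydroxyethoxy replaces the same (3-carboxypropyl)amino on the carbonyl carbon; 3-hydroxypropoxy differs from 2-hydroxyethoxy only in the name of the chain. The step of a number 2.22 log units lower from compound 2 to compound 3 (beyond the scatter) shows how strongly a hydroxy-bearing chain in this position pulls the value down relative to a butoxy chain, so compound 4 should sit between compound 3 and compound 2, but much nearer compound 3. From compound 1, a step within the scatter or only slightly lower is expected: a number 0.01 log units higher from compound 1 to compound 4 (within the scatter). Compound 4 is therefore estimated at -0.8, with a range from -1.3 to -0.3.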

Compound 4, partition coefficient: -0.98
Compound 4: the middle estimate sits 0.18 log units above what was measured; the range from low to high includes it.
By their numbers in this assay, from the lowest: compounds 3, 4 and 1 (each within the scatter of the next, the first and the last beyond it); then compound 2.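

In this assay, 3-hydroxypropoxy on this carbonyl carbon cannot be told apart from (3-carboxypropyl)amino, a number 0.17 log units lower from compound 1 to compound 4 (within the scatter), nor from the shorter chain, a number 0.22 log units higher from compound 3 to compound 4 (within the scatter), so compound 4 lies within the scatter of two compounds whose own gap, a number 0.39 log units lower from compound 1 to compound 3 (beyond the scatter), lies beyond it. The new comparison with the butoxy compound is also the first at matched position along the chain: with hydroxy in place of the terminal methyl, the step is a number 2.00 log units lower from compound 2 to compound 4 (beyond the scatter), which is large and of the same order as a number 2.22 log units lower from compound 2 to compound 3 (beyond the scatter). No measurement beyond these values bears on the reason for these steps.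

As far as these compounds go, compound 3 and compound 4 alone establish no trend with the length of the hydroxy-bearing chain, and whether a longer chain ending in hydroxy would stay within the scatter of compound 4 remains open. Also open, from the compounds shown here alone, is how this assay would read for a carboxylic acid or an amine at the end of a chain joined through oxygen, which would separate the end group from the link to the carbonyl carbon.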